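Carbamoyl on the amino nitrogen of compound 3

This account rests on a few compounds, and the source may have more. Where it says the series, first, only, none or still open, it means among the compounds named here.

Of the compounds shown here, three sharing one core have been tested in a functional assay on the whole organism for inhibition, with Rattus norvegicus as the target, with stated times of 1 h and 3.5 h, at a dose of 100 mg/kg by the oral route; on this read-out higher numbers stand for more inhibition at the one dose given (going by the name of the read-out) and lower numbers for less inhibition. Compound 1 `Nc1nccc(-c2ccccn2)n1` gives 17%, compound 2 `Nc1ncc(-c2ccccc2)c(-c2ccncc2)n1` gives 48% and compound 3 `CC(C)(C)c1nc(N)ncc1-c1ccccc1` gives 46%. Compound 3 thus stands second of the three, with compound 2 close by and compound 1 far lower. For the measured compounds named here, the single measured step, a number 2 percentage points lower from compound 2 to compound 3 (within the scatter), changed a different part of the molecule. Compound 4 `CC(C)(C)c1nc(NC(N)=O)ncc1-c1ccccc1` carries the change (carbamoyl in place of hydrogen on a nitrogen on an aromatic ring). Going by the values given here, no measured step touches this nitrogen, so the data offer no guide to its effect, and the step of a number 1 percentage points lower from compound 3 to compound 4 (within the scatter) is expected to stay within the scatter. In this assay compound 4 is therefore estimated at 45%, between 25% and 65%.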

Compound 4, a percentage reported as inhibition, in the whole organism at one dose (the size of the read-out at that dose, not a potency): 14%
Beside the measured number, compound 4's estimate is 31 percentage points above it; measured number outside the range, below it.
By their numbers in this assay, from the lowest: compounds 4 and 1 (each within the scatter of the next); then compounds 3 and 2 (each within the scatter of the next).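

In this assay, carbamoyl in place of hydrogen on the amino nitrogen gives a number 32 percentage points lower from compound 3 to compound 4 (beyond the scatter) and so removes most of the inhibition. For the compounds shown here, the earlier compounds left this nitrogen unchanged, so this is the first sign that the read-out depends on what this position carries. Amino to ureido is a change of only a few heavy atoms, yet it has a large effect here.

As far as these compounds go, it remains open whether the loss belongs to carbamoyl alone or follows any group on this nitrogen, such as methyl or acetyl. Nothing available gives a reason for the drop.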